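The source may hold more compounds than are shown below. What is called first, only, known or untested is meant among the compounds shown, and "the series" means these compounds.

Measured compounds in a physicochemical assay for solubility, in phosphate buffer, measured as kinetic solubility, with a stated time of 1 h, at pH 7.4; a higher number here means a more soluble compound, a lower number a less soluble compound:
- compound 1 `COc1ccc2nc(C)cc(OCC(=O)NCc3cc(C)cc(C)c3)c2c1`: 92000 nM
- compound 2 `COc1ccc2nc(C)cc(OCC(=O)Nc3cccc(C)c3)c2c1`: 193000 nM
- compound 3 `COc1ccc2nc(C)cc(OCC(=O)Nc3c(C)cccc3C)c2c1`: 112000 nM

Compound 3 sits second highest of the three numbers in this assay, and both of its neighbours are within the usual scatter: compound 1 is close at hand, compound 2 is a little further off, with a 1.7-fold lower number from compound 2 to compound 3 (0.24 log units; within the scatter). Among the measured compounds shown here, the only step that clears the scatter is a 2.1-fold higher number from compound 1 to compound 2 (0.32 log units; beyond the scatter), while a 1.2-fold higher number from compound 1 to compound 3 (0.09 log units; within the scatter) does not.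

Compound 4 `COc1cccc(NC(=O)COc2cc(C)nc3ccc(OC)cc23)c1` is not yet measured in this assay. Its change from compound 3 is 3-methoxyphenyl in place of 2,6-dimethylphenyl on an amide-type nitrogen. For the measured compounds named here, the nearest measured step is the one from compound 2 to compound 3, which swaps a ring bearing one methyl for the 2,6-dimethylphenyl and stays within the scatter; compound 4 reverses that kind of exchange, returning to a ring with a single substituent, now 3-methoxyphenyl. On that basis the expected step of a 1.5-fold higher number from compound 3 to compound 4 (0.18 log units; within the scatter) is a small rise at most, likely within the scatter, with the number for compound 4 expected near that of compound 2.

Compound 4 is therefore estimated at 170000 nM, with a range from 90000 nM to 330000 nM.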

Compound 4, solubility: 35000 nM
For compound 4 the middle estimate is 4.9-fold (0.69 log units) above the measured one, and the stated range ends above it.
By their numbers in this assay, from the lowest: compound 4; then compounds 1, 3 and 2 (each within the scatter of the next, the first and the last beyond it).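

Methoxy in place of methyl on an aromatic carbon is the most direct reading at this position, with a 5.5-fold lower number from compound 2 to compound 4 (0.74 log units; beyond the scatter), so this one exchange on the 3-methylphenyl group is enough to separate two otherwise matched compounds in this assay. Among the compounds shown here, the two other steps into compound 4 also clear the scatter, with a 3.2-fold lower number from compound 3 to compound 4 (0.51 log units; beyond the scatter) and a 2.6-fold lower number from compound 1 to compound 4 (0.42 log units; beyond the scatter), whereas only one of the three steps among the earlier compounds did, so the group on the amide-type nitrogen now shows a wider spread than the methyl-bearing groups alone suggested, and compound 4 stands lowest, the only compound here with a hydrogen-bond acceptor in that group. No measurement in hand bears on why the number falls at this change.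

A single methoxy compound leaves open whether the lower number belongs to methoxy itself or would recur with other oxygen-bearing groups, such as hydroxy or a longer alkoxy chain, on the same ring. As far as these compounds go, how an amine or a carboxylic acid at this place on the ring would read in this assay also remains open, as does whether methoxy would give a step of similar size on the 2,6-dimethylphenyl or 3,5-dimethylbenzyl groups.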